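The source may report more compounds than this note shows. Statements on the series, on what has been measured and on what is new or still open speak of the compounds shown alone.

Measured in a functional assay on MCF7 cells (Homo sapiens) for inhibition, read by MTT assay, with a stated time of 48 h; a lower number here means a stronger inhibitor, a higher number a weaker inhibitor:

Compound 1 `C=C1CN(C)N(c2ccc(Cl)cc2)C1=O` gives 45200 nM
Compound 2 `C=C1C(=O)N(c2ccccc2)N(C)C1c1ccccc1` gives 84400 nM
Compound 3 `C=C1CN(C)N(c2ccc(C)cc2)C1=O` gives 59100 nM

Compound 3 stands second highest of these three numbers. Its nearest neighbour is compound 1, whose number is lower by a margin that sits within the scatter; its furthest is compound 2, whose number is higher, also within the scatter. No step is shown between compound 3 and compound 2, and their two values simply sit close together.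

The next compound, compound 4 `C=C1CN(C)N(c2ccccc2)C1=O`, differs from compound 3 by hydrogen in place of methyl on an aromatic carbon. Among the measured compounds shown here, the one measured step that bears on this position is a 1.3-fold higher number from compound 1 to compound 3 (0.12 log units; within the scatter), an exchange of one substituent for another at the same aromatic carbon that left the number within the scatter. Removing the methyl altogether is a change of similar kind at the same place, so no step beyond the scatter in this assay is expected in either direction.

Compound 4 is therefore estimated at 55000 nM, with a range from 25000 nM to 120000 nM, meaning an expected step of a 1.1-fold lower number from compound 3 to compound 4 (0.03 log units; within the scatter).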

Compound 4, half-maximal inhibitory concentration: 56000 nM
For compound 4 the middle estimate is 1.0-fold (0.01 log units) below the measured one; the range from low to high includes it.
By their numbers in this assay, from the lowest: compounds 1, 4, 3 and 2 (each within the scatter of the next).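

With hydrogen at this aromatic carbon, three groups can now be compared there in this assay: removing the methyl gives a step within the scatter (a 1.1-fold lower number from compound 3 to compound 4 (0.02 log units; within the scatter)), and so does replacing the chloro (a 1.2-fold higher number from compound 1 to compound 4 (0.09 log units; within the scatter)). The earlier compounds shown here compared only two substituents, so compound 4 adds the unsubstituted ring and shows that neither chloro nor methyl is set apart from hydrogen at this position by a step beyond the scatter. Among the compounds shown here, it also provides the first single-place comparison for the phenyl on the saturated ring carbon, where hydrogen in its place again gives a step within the scatter (a 1.5-fold lower number from compound 2 to compound 4 (0.18 log units; within the scatter)), although no information bearing on the reason for these small steps is available.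

As far as these compounds go, whether a methoxy, an amine or a carboxylic acid at the same aromatic carbon would produce a step beyond the scatter remains open. From the compounds shown here alone, it is equally open whether a longer chain or a substituted phenyl on the saturated ring carbon would separate from compound 4, since all four compounds here lie within the scatter of their neighbours.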